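A few compounds are considered here, and "the series" means these few. Any claim that something is new, unique, unknown or untested is made for them only; others in the source may bear on it.

The measured compounds in an assay on microsomes from liver for inhibition of 3-hydroxy-3-methylglutaryl-coenzyme A reductase (Rattus norvegicus); on this read-out lower numbers stand for stronger inhibition and higher numbers for weaker inhibition:

Compound 1, `Cc1cc(C)cc(-c2nc(C(F)(F)F)n(CC[C@@H](O)C[C@@H](O)CC(=O)O)c2-c2ccc(F)cc2)c1`, gives 24 nM.
Compound 2, `Cc1cc(-c2nc(C(F)(F)F)n(CC[C@@H](O)C[C@@H](O)CC(=O)O)c2-c2ccc(F)cc2)cc(C)c1F`, gives 32 nM.
Compound 3, `O=C(O)C[C@H](O)C[C@H](O)CCn1c(C(F)(F)F)nc(-c2ccc(F)cc2)c1-c1ccccc1`, gives 201 nM.

Compound 3 stands highest of the three, and its distance to both compound 1 and compound 2 lies beyond the usual scatter; the two lower numbers of compound 1 and compound 2 sit within the scatter of each other. Compound 4, `COc1cccc(-c2c(-c3ccc(F)cc3)nc(C(F)(F)F)n2CC[C@@H](O)C[C@@H](O)CC(=O)O)c1`, has not yet been measured. The change from compound 3 to compound 4 is methoxy in place of hydrogen on an aromatic carbon, that is, a methoxy in place of hydrogen on an aromatic carbon of the six-membered carbon-only ring, meta to a large group. Among the compounds with values here, only one single-place step has been measured, a 1.3-fold higher number from compound 1 to compound 2 (0.12 log units; within the scatter), a fluoro for hydrogen that stays within the scatter; it does not concern a methoxy. What the numbers of compound 3 against compound 1 and compound 2 do show is that the unsubstituted ring gives the highest number. A modest drop is therefore expected in this assay for compound 4, a 2.9-fold lower number from compound 3 to compound 4 (0.46 log units; beyond the scatter). The estimate for compound 4 is 70 nM, with a range from 25 nM to 200 nM.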

Compound 4, half-maximal inhibitory concentration: 135 nM
The estimate for compound 4 lay 1.9-fold (0.29 log units) below the measured number; the measured number falls inside the stated range.
By their numbers in this assay, from the lowest: compounds 1 and 2 (each within the scatter of the next); then compounds 4 and 3 (each within the scatter of the next).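

In this assay, changing phenyl to 3-methoxyphenyl on compound 3 gives a 1.5-fold lower number from compound 3 to compound 4 (0.17 log units; within the scatter). Within the data shown here, the earlier compounds offered only a fluoro step on a different ring pattern, so this is the one direct reading for a methoxy: on an aromatic carbon, meta to a large group, adding this group of 2 heavy atoms leaves the number within the usual scatter. No measurement available here accounts for this small step.

The compounds shown leave open whether this place would respond differently to another group, such as an amine, a nitrile or a chlorine atom. They also leave open whether a methoxy on another carbon of this ring would give a step beyond the scatter.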